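This account rests on a few compounds, and the source may have more. Where it says the series, first, only, none or still open, it means among the compounds named here.

Measured so far:
- compound 1, `O=[N+]([O-])c1ccc(N/C(=N\O)c2ccccc2)c2nonc12`: 268 nM
- compound 2, `O=[N+]([O-])c1ccc(N/C(=N\O)c2ccccc2F)c2nonc12`: 63 nM
- compound 3, `Cc1cccc(/C(=N/O)Nc2ccc([N+](=O)[O-])c3nonc23)c1`: 163 nM

These three were tested in an assay on isolated protein for inhibition of Indoleamine 2,3-dioxygenase 1 (Homo sapiens), read by spectrophotometry, with a stated time of 1 h; a higher number here means a weaker inhibitor, a lower number a stronger inhibitor. Compound 1 has the highest of the three numbers; compound 3 sits nearest to it, and compound 2 furthest. Compound 4, `O=[N+]([O-])c1ccc(N/C(=N\O)c2cccc(Cl)c2)c2nonc12`, has not yet been measured. It differs from compound 1 in one place: chloro in place of hydrogen on an aromatic carbon.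

For the measured compounds named here, two measured steps bear on this change. Putting a fluoro in place of hydrogen gave a 4.3-fold lower number from compound 1 to compound 2 (0.63 log units; beyond the scatter). Putting a methyl in place of hydrogen, so that phenyl became 3-methylphenyl, gave a 1.6-fold lower number from compound 1 to compound 3 (0.22 log units; within the scatter). The change to compound 4 also turns phenyl into a 3-substituted phenyl, here 3-chlorophenyl, so the step from compound 1 to compound 3 is the closer guide, while the step from compound 1 to compound 2 shows that a halogen can bring a modest lowering. A small lowering is therefore expected, a 2.1-fold lower number from compound 1 to compound 4 (0.31 log units; beyond the scatter), which may or may not exceed the scatter. Compound 4 is estimated at 130 nM, between 55 nM and 310 nM.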

Compound 4, half-maximal inhibitory concentration: 184 nM
The estimate for compound 4 lay 1.4-fold (0.15 log units) below the measured number; measured number inside the range.
By their numbers in this assay, from the lowest: compound 2; then compounds 3, 4 and 1 (each within the scatter of the next).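

In this assay, chloro in place of hydrogen on this aromatic carbon gives a 1.5-fold lower number from compound 1 to compound 4 (0.16 log units; within the scatter), so 3-chlorophenyl cannot be told apart from plain phenyl. Swapping methyl for chloro at that same place gives a 1.1-fold higher number from compound 3 to compound 4 (0.05 log units; within the scatter), which means that neither group yet separates from hydrogen or from the other. Only the 2-fluorophenyl group stands apart, with a 2.9-fold higher number from compound 2 to compound 4 (0.47 log units; beyond the scatter), and nothing measured here gives a cause for that gap.

Compound 2 and compound 4 differ in both the halogen and its place on the ring, leaving open which of the two carries the gap, a question that a chloro placed where compound 2 has its fluoro could settle. Also open, as far as these compounds go, is how an amine or a carboxylic acid would read in the place of the chloro.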